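Sulfonyl aryl substituent on the pyrazoline series: fluoro to trifluoromethyl

The source may hold more compounds than are shown below. What is called first, only, known or untested is meant among the compounds shown, and "the series" means these compounds.

Working notes. The series is tested in a functional assay on NCI-H1975 cells (Homo sapiens) for inhibition, read by sulforhodamine B assay, tested at 10 uM; on this read-out lower numbers stand for less inhibition and higher numbers for more inhibition at the one concentration tested (going by the name of the read-out). Compound 1 `CN1CCN(c2ccc(C3=NN(S(=O)(=O)c4ccc(C(F)(F)F)cc4)C(c4ccc(N(C)C)cc4)C3)cc2)CC1` gives 18.9%. Compound 2 `CN(C)c1ccc(C2CC(c3ccc(-n4cncn4)cc3)=NN2S(C)(=O)=O)cc1` gives -3.1%. Compound 3 `CN(C)c1ccc(C2CC(c3ccc(-n4cncn4)cc3)=NN2S(=O)(=O)c2ccc(F)cc2)cc1` gives -0.5%, the second highest of the three numbers; compound 2 lies near it within the scatter, while compound 1 sits higher, beyond the scatter, but differs from compound 3 in two places, so its value alone is noted.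

Compound 4 `CN(C)c1ccc(C2CC(c3ccc(-n4cncn4)cc3)=NN2S(=O)(=O)c2ccc(C(F)(F)F)cc2)cc1` is the next member. The change is trifluoromethyl in place of fluoro on an aromatic carbon.

Among the measured compounds shown here, the only measured step on the sulfonyl substituent, a number 2.6 percentage points higher from compound 2 to compound 3 (within the scatter), is within the scatter. For the measured compounds named here, no step touches trifluoromethyl in place of fluoro here; compound 1 carries the entering group but is not a single-point comparison. The expected step is therefore a number 5.5 percentage points higher from compound 3 to compound 4 (within the scatter), within the scatter. Compound 4 is estimated at 5%, within -10% to 22%.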

Compound 4, a percentage reported as inhibition, at one concentration (the size of the read-out at that concentration, not a potency): 5.5%
The estimate for compound 4 lay 0.5 percentage points below the measured number; low and high end bracket the measured number.
By their numbers in this assay, from the lowest: compounds 2, 3 and 4 (each within the scatter of the next); then compound 1.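

In this assay, trifluoromethyl in place of fluoro on the aromatic carbon gives a number 6 percentage points higher from compound 3 to compound 4 (within the scatter), and 4-(trifluoromethyl)phenyl in place of methyl on the sulfonyl sulfur gives a number 8.6 percentage points higher from compound 2 to compound 4 (within the scatter), so none of the three sulfonyl substituents separates from the others. Among the compounds shown here, the first single-place step beyond the scatter lies away from the sulfonyl group: 1H-1,2,4-triazol-1-yl in place of 4-methylpiperazin-1-yl gives a number 13.4 percentage points lower from compound 1 to compound 4 (beyond the scatter). Open, going by these compounds, is whether an amine or a carboxylic acid on that aromatic carbon would give a step beyond the scatter. Also open, on these data alone, is whether fluoro or methyl on the sulfonyl side keeps the same relation when 4-methylpiperazin-1-yl is present. No measurement at hand accounts for these steps.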